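Aryl swap on the core: benzothiazolyl for fluorophenyl

A few compounds are considered here, and "the series" means these few. Any claim that something is new, unique, unknown or untested is made for them only; others in the source may bear on it.

Compound 2 `Nc1ccc(S(=O)(=O)N2CCN(c3ncc(C(O)(C(F)(F)F)C(F)(F)F)cc3-c3cccc(F)c3)CC2)cn1` gives the lowest number of the three measured in an ADME assay (liver) for metabolic stability, with Liver microsome (Rattus norvegicus) as the target, using microsomes and NADPH, with a stated time of 30 min, tested at 1 uM (a higher number here means faster removal of the compound, a lower number slower removal), at 52 mL.min-1.g-1. Compound 1 `CC(C)n1cc(-c2cc(C(O)(C(F)(F)F)C(F)(F)F)cnc2N2CCN(S(=O)(=O)c3ccc(N)nc3)CC2)cn1` gives 198 mL.min-1.g-1 and compound 3 `COc1ccc(-c2cc(C(O)(C(F)(F)F)C(F)(F)F)cnc2N2CCN(S(=O)(=O)c3ccc(N)nc3)CC2)cn1` gives 265 mL.min-1.g-1; the step of a 3.8-fold lower number from compound 1 to compound 2 (0.58 log units; beyond the scatter) and the step of a 5.1-fold higher number from compound 2 to compound 3 (0.71 log units; beyond the scatter) both lie beyond the scatter. Compound 4 `Nc1ccc(S(=O)(=O)N2CCN(c3ncc(C(O)(C(F)(F)F)C(F)(F)F)cc3-c3ccc4scnc4c3)CC2)cn1` differs from compound 2 in one place: 1,3-benzothiazol-5-yl in place of 3-fluorophenyl on an aromatic carbon. Both measured steps that change the group on this same aromatic carbon bear on the question, and in each the 3-fluorophenyl compound gave the lower number. A rise is therefore expected, of about a 2.9-fold higher number from compound 2 to compound 4 (0.46 log units; beyond the scatter). The estimate for compound 4 in this assay is 150 mL.min-1.g-1, with a range from 60 mL.min-1.g-1 to 380 mL.min-1.g-1.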

Compound 4, intrinsic clearance in microsomes: 147 mL.min-1.g-1
Estimate against measurement, compound 4: 1.0-fold (0.01 log units) above; the measured number falls inside the stated range.
By their numbers in this assay, from the lowest: compound 2; then compounds 4, 1 and 3 (each within the scatter of the next).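

At this aromatic carbon in this assay, 1,3-benzothiazol-5-yl does not keep the low number of 3-fluorophenyl: a 2.8-fold higher number from compound 2 to compound 4 (0.45 log units; beyond the scatter). It instead groups with the two heteroaryl substituents, with a 1.8-fold lower number from compound 3 to compound 4 (0.26 log units; within the scatter) and a 1.3-fold lower number from compound 1 to compound 4 (0.13 log units; within the scatter). Within the data shown here, of the four groups, 3-fluorophenyl alone now stands apart, as compound 2 is the only compound with steps beyond the scatter to all the others.

Going by these compounds, how a simple phenyl, an aminomethyl or a carboxylic acid on this carbon would compare remains open. Nothing measured here accounts for the gap between compound 2 and the others.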